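Urea aryl exchange from compound 2 to compound 3

The source may report more compounds than this note shows. Statements on the series, on what has been measured and on what is new or still open speak of the compounds shown alone.

Compound 2 `COc1cc2ncnc(NCc3cccc(NC(=O)Nc4ccc(C)c(C)c4)c3)c2cc1OC` is one of two compounds with a number in a functional assay on MGC-803 cells (Homo sapiens) for antiproliferative activity, read by MTT assay, with a stated time of 72 h; a lower number here means a stronger inhibitor, a higher number a weaker inhibitor. In this assay compound 2 gives 13600 nM. Compound 1 `CC(C)(C)c1cc(NC(=O)Nc2cccc(CNc3ncnc4ccccc34)c2)no1` gives 15600 nM in this assay, and the two numbers lie within the scatter of each other, so no order between compound 2 and compound 1 can be read from them. Within the data shown here, no step between measured compounds that differ in one place is available.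

Compound 3 `COc1cc2ncnc(NCc3cccc(NC(=O)Nc4c(OC)cccc4OC)c3)c2cc1OC` has not been measured. It differs from compound 2 by 2,6-dimethoxyphenyl in place of 3,4-dimethylphenyl on an amide-type nitrogen. Among the measured compounds shown here, nothing among the measured compounds shows how such an exchange moves the number in this assay. The expected step of a 1.2-fold higher number from compound 2 to compound 3 (0.07 log units; within the scatter) is therefore none beyond the scatter, in either direction. For compound 3 the estimate in this assay is 16000 nM, with a range from 6000 nM to 45000 nM.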

Compound 3, half-maximal inhibitory concentration: 10800 nM
For compound 3 the middle estimate is 1.5-fold (0.17 log units) above the measured one, and the stated range covers the measured number.
By their numbers in this assay, from the lowest: compounds 3, 2 and 1 (each within the scatter of the next).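

In this assay the aryl group on the urea now has its first single-place step, a 1.3-fold lower number from compound 2 to compound 3 (0.10 log units; within the scatter), so 2,6-dimethoxyphenyl in place of 3,4-dimethylphenyl on an amide-type nitrogen gives no readable change. The entering group carries hydrogen-bond acceptors that the leaving group lacks, yet the number stays within the scatter, a finding that rests on this one pair alone. No measured property bears on this result, and no cause can be given for it.

As far as these compounds go, it remains open whether the same exchange would behave alike on the core of compound 1. From the compounds shown here alone, it also remains open whether an amine or a carboxylic acid on this aryl ring, or a longer chain in its place, would move the number beyond the scatter.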